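The source may report more compounds than this note shows. Statements on the series, on what has been measured and on what is new or still open speak of the compounds shown alone.

Measured so far in an ADME assay on MT4 cells (Homo sapiens) for cytotoxicity, read by MTT assay; a higher number here means that more compound is tolerated, a lower number that less compound is tolerated:

- Compound 1 `Cc1cc(C)cc(S(=O)(=O)c2c(C(=O)NCc3ccc(Cl)cc3)[nH]c3ccc(Cl)cc23)c1`: > 51200 nM (a limit of the assay)
- Compound 2 `Cc1cc(C)cc(S(=O)(=O)c2c(C(=O)NCc3ccccc3[N+](=O)[O-])[nH]c3ccc(Cl)cc23)c1`: > 50200 nM (a limit of the assay)

Neither entry is a true number. Compound 2 stands at > 50200 nM, which is only a limit. Compound 1 also gives only a limit, > 51200 nM.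

The next compound to consider is compound 3 `Cc1cc(C)cc(S(=O)(=O)c2c(C(=O)NCc3ccc([N+](=O)[O-])cc3)[nH]c3ccc(Cl)cc23)c1`, which has the same atoms as compound 2, joined differently: 4-nitrophenyl in place of 2-nitrophenyl on a saturated chain carbon bound to an amide-type nitrogen. Here, 4-nitrophenyl takes the place of 2-nitrophenyl on a saturated chain carbon bound to an amide-type nitrogen.

One measured step changes this same place: a step that the two limits leave unreadable from compound 1 to compound 2. It swaps 4-chlorophenyl for 2-nitrophenyl, but it gives no size to carry forward. For the measured compounds named here, with only that unreadable step as a guide, no shift beyond the usual scatter is expected in this assay, in either direction, and another limit is the likeliest result. The expected change is a number no higher from compound 2 to compound 3 (the limit leaves the size open). For compound 3 the estimate is 50000 nM, with an expected range of 25000 nM to 55000 nM.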

Compound 3, half-maximal cytotoxic concentration: > 50200 nM
Compound 3: only a limit was reported (the forecaster's own chance of this, stated with the estimate: 80%); middle value at least 1.0-fold (0.00 log units) from the limit.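

In this assay, for the compounds shown here, compound 1, compound 2 and compound 3 all give only limits, and no step among them can be read, neither 4-nitrophenyl for 2-nitrophenyl nor nitro for chloro. The compounds shown leave open the true half-maximal cytotoxic concentration of each one, and whether either change shifts it at all.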